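A few compounds are considered here, and "the series" means these few. Any claim that something is new, unique, unknown or untested is made for them only; others in the source may bear on it.

Measured so far:
Compound 1 `CN1CCC(C(=O)N2Cc3c(NC(=O)Nc4cccc(F)c4)n[nH]c3C2(C)C)CC1` gives > 225000 nM in a physicochemical assay for solubility, at pH 7 (a higher number here means a more soluble compound, a lower number a less soluble compound), a limit of the assay.
Compound 2 `CN1CCC(C(=O)N2Cc3c(NC(=O)c4ccsc4)n[nH]c3C2(C)C)CC1` gives > 225000 nM in this assay, also a limit.
Compound 3 `CN1CCC(C(=O)N2Cc3c(NC(=O)c4ccc(Cl)cc4)n[nH]c3C2(C)C)CC1` gives > 225000 nM in this assay, again a limit.

Compound 3 therefore stands only at a limit, together with every other value shown, because of the limit of > 225000 nM in this assay, at which 3 of the 3 values shown sit. The steps measured among these compounds, a step that the two limits leave unreadable from compound 1 to compound 2, a step that the two limits leave unreadable from compound 1 to compound 3 and a step that the two limits leave unreadable from compound 2 to compound 3, are all unreadable between two limits. Compound 4 `CN1CCC(C(=O)N2Cc3c(NC(=O)c4cc(F)cc(F)c4)n[nH]c3C2(C)C)CC1` differs from compound 3 by 3,5-difluorophenyl in place of 4-chlorophenyl on a carbonyl carbon. Within the data shown here, no measured step reads a size for this kind of change, so no shift in this assay beyond the scatter is expected. Compound 4 is estimated to give 225000 nM, between 80000 nM and 225000 nM, a step of a number no higher from compound 3 to compound 4 (the limit leaves the size open) that is expected to remain at the limit.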

Compound 4, solubility: > 225000 nM
Compound 4: only a limit was reported (the forecaster's own chance of this, stated with the estimate: 80%); the middle value lies on the limit itself.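

Among these compounds, no step from compound 1, compound 2 or compound 3 to compound 4 can be read in this assay, since all four compounds sit at one limit: the limit of > 225000 nM in this assay, at which 4 of the 4 values shown sit.

The compounds shown leave open how these groups on the carbonyl carbon rank against one another, and which change would bring a value off the limit.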